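The source may report more compounds than this note shows. Statements on the series, on what has been measured and on what is new or still open speak of the compounds shown alone.

Compound 1 `O=C1N/C(=N\Cc2ccc(C(F)(F)F)cc2)S/C1=C1/CCNC(=O)c2[nH]ccc21`: > 100000 nM
Compound 2 `O=C1N/C(=N\Cc2ccc(Cl)cc2)S/C1=C1/CCNC(=O)c2[nH]ccc21`: > 100000 nM
Compound 3 `CC(C)(C)c1ccc(C/N=C2\NC(=O)/C(=C3\CCNC(=O)c4[nH]ccc43)S2)cc1`: > 100000 nM

All three compounds were tested in a functional assay on HCT-116 cells (Homo sapiens) for inhibition, read by MTT assay, with a stated time of 48 h (a lower number here means a stronger inhibitor, a higher number a weaker inhibitor), and each entry is a limit of the assay, not a number. They share one reading: the limit of > 100000 nM in this assay, at which 3 of the 3 values shown sit.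

Compound 3 therefore has only a limit, > 100000 nM. Compound 4 `O=C1N/C(=N\Cc2ccc(F)cc2)S/C1=C1/CCNC(=O)c2[nH]ccc21` carries fluoro in place of tert-butyl on an aromatic carbon, para to a large group: fluoro in place of tert-butyl on an aromatic carbon.

Among the compounds with values here, three measured steps bear on this change, as each swaps one group on an aromatic carbon: a step that the two limits leave unreadable from compound 1 to compound 2, a step that the two limits leave unreadable from compound 1 to compound 3 and a step that the two limits leave unreadable from compound 2 to compound 3. None of them has a readable size, so they offer no direction and no clear reason to expect a change in this assay. The likeliest outcome is another limit, as compound 2 gives with chloro, again a limit at > 100000 nM.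

The expected result is a step that the limit leaves unreadable from compound 3 to compound 4. Compound 4 is estimated at 120000 nM, with an expected range of 50000 nM to 300000 nM.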

Compound 4, half-maximal inhibitory concentration: 16900 nM
Compound 4: the middle estimate sits 7.1-fold (0.85 log units) above what was measured; the whole stated range lies above it.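

In this assay, the group on this aromatic carbon, para to a large group, can clearly change the reading: fluoro in place of tert-butyl gives an at least 5.9-fold lower number from compound 3 to compound 4 (0.77 log units; beyond the scatter), fluoro in place of chloro gives an at least 5.9-fold lower number from compound 2 to compound 4 (0.77 log units; beyond the scatter), and fluoro in place of trifluoromethyl gives an at least 5.9-fold lower number from compound 1 to compound 4 (0.77 log units; beyond the scatter). The steps among compound 1, compound 2 and compound 3 cannot be read, as each of these compounds has a limit of the assay rather than a number: the limit of > 100000 nM in this assay, at which 3 of the 4 values shown sit. Among the four groups shown, only fluoro gives a measurable number, so the effect is not shared by chloro, tert-butyl or trifluoromethyl.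

The compounds shown leave open whether a plain hydrogen, a methoxy group or an amine at this place would also give a measurable number. From the compounds shown here alone, the true size of the three steps also remains unknown, since each is only a minimum.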